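Chloro on the Phenyl Ring and Toxicity toward Liver Cells

This account rests on a few compounds, and the source may have more. Where it says the series, first, only, none or still open, it means among the compounds named here.

Compound 1 `Cc1ccccc1-n1cc(-c2cccc(NS(=O)(=O)c3c[nH]c(=O)[nH]c3=O)c2)nn1` sets the only numerical point of reference in this set. In an ADME assay on L02 cells (Homo sapiens) for cytotoxicity, read by MTT assay, with a stated time of 24 h (on this read-out higher numbers stand for lower toxicity in this test and lower numbers for higher toxicity in this test), compound 1 gives 15300 nM. Compound 2 `O=c1[nH]cc(S(=O)(=O)Nc2ccc(-c3cn(-c4ccccc4)nn3)cc2)c(=O)[nH]1` shares the sulfonamide-linked core of compound 1 but is arranged differently at both ends. In this assay compound 2 is reported as "not toxic" (no number reported), so no single number exists for it; its result can only be described as lying without a figure to set beside the value of compound 1, and nothing further can be said of the distance between the two.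

Compound 3 `O=c1[nH]cc(S(=O)(=O)Nc2ccc(-c3cn(-c4ccccc4Cl)nn3)cc2)c(=O)[nH]1` is derived from compound 2 by the change (chloro in place of hydrogen on an aromatic carbon), in words a chloro in place of hydrogen on an aromatic carbon. Within the data shown here, no measured pair in this set carries that change, so the size of the step cannot be read from the data. Given that compound 2 registered no toxicity at all, a step of modest size, within the scatter of this assay or not far beyond it, is expected. Compound 3 is therefore estimated to give 40000 nM, with a range from 12000 nM to 150000 nM, and a real chance that again only a limit is reported.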

Compound 3, half-maximal cytotoxic concentration: 19300 nM
Estimate against measurement, compound 3: 2.1-fold (0.32 log units) above; the range from low to high includes it.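

No step can be read for compound 3: compound 2 has no number in this assay, and compound 1 differs from compound 3 in more than one place. The compounds shown leave open what a chloro in place of hydrogen on the aromatic carbon does to this read-out. Nothing available bears on the result for compound 3.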